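This account rests on a few compounds, and the source may have more. Where it says the series, first, only, none or still open, it means among the compounds named here.

Working notes on the series. In a functional assay on MCF7 cells (Homo sapiens) for cytotoxicity, read by MTT assay, with a stated time of 72 h (a higher number here means a weaker inhibitor, a lower number a stronger inhibitor), compound 1 `O=C(N/N=C/c1ccc(F)cc1)Nc1cc2c(Nc3ccc(F)c(Cl)c3)ncnc2cc1O[C@H]1CCOC1` gives 28200 nM and compound 2 `O=C(N/N=C/c1ccc(F)cc1Cl)Nc1cc2c(Nc3ccc(F)c(Cl)c3)ncnc2cc1O[C@H]1CCOC1` gives 32200 nM. Among the compounds with values here, the only measured step is a 1.1-fold higher number from compound 1 to compound 2 (0.06 log units; within the scatter), from chloro in place of hydrogen on an aromatic carbon. It lies within the scatter, so compound 2 stands level with compound 1 and neither can be ranked above the other.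

Next is compound 3 `O=C(N/N=C/c1ccc(O)c(Br)c1)Nc1cc2c(Nc3ccc(F)c(Cl)c3)ncnc2cc1O[C@H]1CCOC1`, which brings 3-bromo-4-hydroxyphenyl in place of 2-chloro-4-fluorophenyl on a carbon with a double bond to nitrogen. This exchanges the whole substituted ring, a larger change than the one measured so far. Within the data shown here, no measured compound carries a bromo or hydroxy group, so the data give no direct guide to either.

Among the measured compounds shown here, the sole precedent is the small step of a 1.1-fold higher number from compound 1 to compound 2 (0.06 log units; within the scatter), and on that evidence no step beyond the scatter is expected in this assay, in either direction. The expected step is a 1.3-fold lower number from compound 2 to compound 3 (0.11 log units; within the scatter). For compound 3 the estimated value is 25000 nM, with an expected range from 8000 nM to 60000 nM.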

Compound 3, half-maximal inhibitory concentration: 2690 nM
Estimate against measurement, compound 3: 9.3-fold (0.97 log units) above, and the stated range ends above it.
By their numbers in this assay, from the lowest: compound 3; then compounds 1 and 2 (each within the scatter of the next).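

In this assay, the group on the carbon with a double bond to nitrogen proves able to shift the number substantially: a 12-fold lower number from compound 2 to compound 3 (1.08 log units; beyond the scatter), and a 10-fold lower number from compound 1 to compound 3 (1.02 log units; beyond the scatter), whereas the earlier chloro step stayed within the scatter. Within the data shown here, compound 3 therefore separates from both earlier compounds, and the two large steps show that the exchange of the whole substituted ring matters here in a way the single chloro change did not reveal. The entering 3-bromo-4-hydroxyphenyl has the same 8 heavy atoms as the leaving 2-chloro-4-fluorophenyl but brings 1 hydrogen-bond donor and 1 hydrogen-bond acceptor in place of 0 of each, and nothing on hand explains the gain in terms of any of these differences.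

Bromo and hydroxy enter together, so the compounds shown do not divide the step between them, and neither group appears alone on the ring. Also open, going by these compounds, is whether a methoxy group in place of the hydroxy, or an amine or a carboxylic acid on the same ring, would hold the number of compound 3 2690 nM.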